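The source may hold more compounds than are shown below. What is called first, only, known or untested is meant among the compounds shown, and "the series" means these compounds.

Measured so far, in a functional assay on the whole organism (stomach) with Rattus norvegicus as the target; on this read-out lower numbers stand for an effect already at smaller amounts and higher numbers for an effect only at larger amounts of compound:
- compound 1, `N=C(S)CCCCn1nc(-c2ccccc2)ccc1=O`: > 100 mg/kg, a limit of the assay rather than a number
- compound 2, `CC(Cn1nc(-c2ccccc2)ccc1=O)C(=N)S`: 28.1 mg/kg
- compound 3, `N=C(S)CCn1nc(-c2ccccc2)c2ccccc2c1=O`: 66.5 mg/kg

Within the data shown here, compound 1 therefore stands at the edge of what this assay reports: it is the one compound for which only the limit of > 100 mg/kg in this assay, at which 1 of the 3 values shown sits, is known, with no measured number behind it. Among the measured compounds shown here, the single step between compounds that differ in one place, an at least 3.5-fold lower number from compound 1 to compound 2 (0.55 log units; beyond the scatter), shows that trimming and branching the chain that carries the sulfur-bearing end group can move the read-out beyond the scatter, although the size of that step is itself only a lower bound because compound 1 is held at the limit of > 100 mg/kg in this assay, at which 1 of the 3 values shown sits.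

Compound 4, `CN(C)C(=S)CCCCCn1nc(-c2ccccc2)ccc1=O`, differs from compound 1 as follows: a group of 6 heavy atoms (4 carbon, 1 nitrogen, 1 sulfur; no ring) in place of a group of 3 heavy atoms (1 carbon, 1 nitrogen, 1 sulfur; no ring), on a saturated chain carbon, four bonds along the chain from an aromatic nitrogen. For the measured compounds named here, no measured step touches this end group; the step from compound 1 to compound 2 alters the chain rather than the group at its end, so it offers only indirect guidance. With compound 1 resting at the limit, compound 4 is expected to stay near that same region, estimated at 100 mg/kg within 40 mg/kg to 300 mg/kg. This expectation amounts to a step of a number no higher from compound 1 to compound 4 (the limit leaves the size open), with a fair chance that the assay again returns only a limit.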

Compound 4, dose for half-maximal effect: 100 mg/kg
Compound 4: middle estimate and measured number agree at the digits printed; low and high end bracket the measured number.
By their numbers in this assay, from the lowest: compound 2; then compounds 3 and 4 (each within the scatter of the next).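

Where compound 1 carries an end group with 2 hydrogen-bond donors, compound 4 carries a larger one with 0, and in this assay compound 4 gives a measured 100 mg/kg. A group without those donors at this place, on a saturated chain carbon, four bonds along the chain from an aromatic nitrogen, gives a number no higher from compound 1 to compound 4 (the limit leaves the size open) and can therefore still return a number from the assay. Compound 1 holds only a limit, > 100 mg/kg, which is a limit of the assay and not a number, so the change from its end group to the larger one shows a direction at most, and its size cannot be read for this reason: the limit of > 100 mg/kg in this assay, at which 1 of the 4 values shown sits.

The entering group differs in both its heavy atoms and its hydrogen-bond donors, so the compounds shown do not separate these two differences. Also open, from the compounds shown here alone, is how a carboxylic acid, a piperidine ring or an oxygen-bearing amide in place of the sulfur-bearing end group would read in this assay on this same chain.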